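Notes on extending compound 3 with a further ester

A few compounds are considered here, and "the series" means these few. Any claim that something is new, unique, unknown or untested is made for them only; others in the source may bear on it.

Measured in a functional assay, read by WST assay (on this read-out lower numbers stand for stronger inhibition and higher numbers for weaker inhibition), so far
- compound 1 `CC1(C)OC(=O)[C@@]2(C=C[C@@H](O)[C@H](OC(=O)/C=C/c3ccc(O)c(O)c3)C2)O1` gives 1.5 ug/mL
- compound 2 `CC1(C)OC(=O)[C@@]2(C=C[C@@H](OC(=O)/C=C/c3ccc(O)c(O)c3)[C@H](OC(=O)/C=C/c3ccc(O)c(O)c3)C2)O1` gives 2 ug/mL
- compound 3 `O=C(/C=C/c1ccc(O)c(O)c1)O[C@@H]1C[C@](O)(C(=O)O)C=C[C@H]1O` gives 0.5 ug/mL

Compound 3 has the lowest number of the three and is the most potent, with both other compounds beyond the scatter from it. Compound 4 `O=C(/C=C/c1ccc(O)c(O)c1)O[C@@H]1C=C[C@@](O)(C(=O)O)C[C@H]1OC(=O)/C=C/c1ccc(O)c(O)c1` differs from compound 3 by one change: (2-(3,4-dihydroxyphenyl)ethenyl)carbonyl in place of hydrogen on an oxygen on a saturated carbon. This places (2-(3,4-dihydroxyphenyl)ethenyl)carbonyl in place of hydrogen on an oxygen on a saturated carbon. For the measured compounds named here, only one measured step is of the same kind, namely a 1.3-fold higher number from compound 1 to compound 2 (0.12 log units; within the scatter). That step lies within the scatter, but it was measured on the core of compound 1, which differs from the core of compound 3. Going by these compounds, the evidence is therefore a single pair, and its transfer to compound 3 is untested. No change beyond the scatter is expected in this assay, with a slight rise in the number as the likelier direction. The expected step is a 1.3-fold higher number from compound 3 to compound 4 (0.11 log units; within the scatter). The estimated value for compound 4 is 0.65 ug/mL, with an expected range from 0.3 ug/mL to 1.5 ug/mL.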

Compound 4, half-maximal inhibitory concentration: 1.9 ug/mL
Compound 4: middle estimate off by 2.9-fold (0.47 log units), on the low side; measured number above the stated range.
By their numbers in this assay, from the lowest: compound 3; then compounds 1, 4 and 2 (each within the scatter of the next).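

In this assay, (2-(3,4-dihydroxyphenyl)ethenyl)carbonyl in place of hydrogen on this oxygen on a saturated carbon is not neutral on the core of compound 3: a 3.8-fold higher number from compound 3 to compound 4 (0.58 log units; beyond the scatter). On this core, the compound with hydrogen on the oxygen has the lower number, so the added ester costs potency beyond the scatter. The earlier pair alone did not reveal this dependence on the core: the same change on two cores in this assay, a 1.3-fold higher number (0.12 log units; within the scatter) from compound 1 to compound 2 and a 3.8-fold higher number (0.58 log units; beyond the scatter) from compound 3 to compound 4, 2.9-fold (0.45 log units) apart, beyond the scatter of two such steps.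

Going by these compounds, whether a smaller group on the same oxygen, such as an acetyl ester or a methyl ether, would also raise the number on the core of compound 3 remains open. For the compounds shown here, also open is which feature of the two cores sets the gap between the two steps, with only one pair on each core to go on.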